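A few compounds are considered here, and "the series" means these few. Any claim that something is new, unique, unknown or untested is made for them only; others in the source may bear on it.

Measured so far in an assay on COS-1 cells for displacement of a labelled ligand from sodium-dependent dopamine transporter (Homo sapiens); a higher number here means a weaker inhibitor, a lower number a stronger inhibitor:
compound 1 `COC(=O)C1=C(c2cccc(Cl)c2)CCCC1` gives 22000 nM;
compound 2 `COC(=O)C1=C(c2ccc(OC(F)(F)F)cc2)CCCC1` gives 1660000 nM;
compound 3 `COC(=O)C1=C(c2ccccc2)CCCC1` gives 630000 nM.

Compound 3 stands second highest of the three numbers, with compound 2 nearest and compound 1 furthest. Compound 4 `COC(=O)C1=C(c2cccc([N+](=O)[O-])c2)CCCC1` differs from compound 3 by nitro in place of hydrogen on an aromatic carbon, meta to a large group. For the measured compounds named here, two measured steps bear on this change: a 29-fold higher number from compound 1 to compound 3 (1.46 log units; beyond the scatter), and a 2.6-fold lower number from compound 2 to compound 3 (0.42 log units; beyond the scatter). Both show that a group on the aromatic ring shifts the number in this assay, and the larger step went toward a lower number. A step toward a lower number is therefore expected for compound 4, roughly an 11-fold lower number from compound 3 to compound 4 (1.02 log units; beyond the scatter), though smaller than the step of compound 1, as the two measured steps point opposite ways. Compound 4 is estimated at 60000 nM, within 15000 nM to 250000 nM.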

Compound 4, inhibition constant: 239000 nM
Estimate against measurement, compound 4: 4.0-fold (0.60 log units) below; low and high end bracket the measured number.
By their numbers in this assay, from the lowest: compound 1; then compound 4; then compound 3; then compound 2.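

At this position, meta to a large group, nitro in place of hydrogen also lowers the number in this assay, giving a 2.6-fold lower number from compound 3 to compound 4 (0.42 log units; beyond the scatter). Until now only chloro had shown such a drop here, and the two groups are far from equal, with nitro in place of chloro giving an 11-fold higher number from compound 1 to compound 4 (1.04 log units; beyond the scatter). Nothing measured here accounts for that gap between chloro and nitro. As far as these compounds go, what an amine or a carboxylic acid would give at this position remains open, as does whether chloro and nitro keep their order with another ester on the shared core.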